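Swapping a bromo ring for a dimethyl ring

The source may report more compounds than this note shows. Statements on the series, on what has been measured and on what is new or still open speak of the compounds shown alone.

In a functional assay on SMMC-7721 cells (Homo sapiens) for inhibition, read by CCK-8 assay, with a stated time of 72 h, tested at 8 uM (a higher number here means more inhibition of growth at the concentration tested, a lower number less inhibition of growth), compound 1 `Cc1ccc(SCc2ccc(C(=O)Nc3ccccc3N)cc2)cc1` gives 82.7%. Compound 2 `Nc1ccccc1NC(=O)c1ccc(CSc2ccc(Br)cc2)cc1` gives 25.3%, the lower of the two numbers and clearly apart from compound 1. Among the measured compounds shown here, the only measured step is a number 57.4 percentage points lower from compound 1 to compound 2 (beyond the scatter), a large drop that comes with bromo in place of methyl on an aromatic carbon. Compound 3 `Cc1cc(C)cc(SCc2ccc(C(=O)Nc3ccccc3N)cc2)c1` differs from compound 2 at one place: 3,5-dimethylphenyl in place of 4-bromophenyl on a sulfur. The bromo is gone and methyl groups stand on the ring again, so that single step, read backwards, is the best guide. For the measured compounds named here, the methyl-bearing compound 1 reached 82.7%, which points to a rise, though no measured compound carries this exact ring. The expected change is a number 36.7 percentage points higher from compound 2 to compound 3 (beyond the scatter), a large upward step. For compound 3 the estimated value is 62%, with an expected range from 35% to 88%.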

Compound 3, percent growth inhibition at one concentration: 85.1%
The estimate for compound 3 lay 23.1 percentage points below the measured number; measured number inside the range.
By their numbers in this assay, from the lowest: compound 2; then compounds 1 and 3 (each within the scatter of the next).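

The change to 3,5-dimethylphenyl on the sulfur brings a number 59.8 percentage points higher from compound 2 to compound 3 (beyond the scatter) and so shows that the low number of compound 2 is not fixed by the shared core: a different ring at this place restores strong growth inhibition. The move from a single methyl to two, with 3,5-dimethylphenyl in place of 4-methylphenyl, brings a number 2.4 percentage points higher from compound 1 to compound 3 (within the scatter) and so gives no readable difference, which means these two methyl-bearing rings cannot be ranked. Nothing measured here explains why the bromo compound stands so far from both methyl compounds.

Going by these compounds, it remains open whether the low number belongs to bromo alone or would also appear with chloro or fluoro on the ring. A plain phenyl ring, or a methoxy group or an amine on it, would show how much this place depends on methyl groups at all.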